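Phenyl in Place of Thiophene on the Shared Core

This account rests on a few compounds, and the source may have more. Where it says the series, first, only, none or still open, it means among the compounds named here.

Compound 1 `COc1ccc(S(=O)(=O)N2CCc3cccc(-c4ccc(O)cc4)c32)cc1`: 82.6 nM
Compound 2 `COc1ccc(S(=O)(=O)N2CCc3cccc(-c4ccncc4)c32)cc1`: 69.5 nM
Compound 3 `COc1ccc(S(=O)(=O)N2CCc3cccc(-c4cccs4)c32)cc1`: 165 nM

In a functional assay on MKN-45 cells (Homo sapiens) for inhibition, with a stated time of 72 h (a higher number here means a weaker inhibitor, a lower number a stronger inhibitor), compound 3 stands with the highest of the three numbers; its nearest neighbour is compound 1, a step within the scatter, and its furthest is compound 2, a step beyond the scatter. Compound 4 `COc1ccc(S(=O)(=O)N2CCc3cccc(-c4ccccc4)c32)cc1` is made from compound 3 by phenyl in place of thiophen-2-yl on an aromatic carbon. Among the compounds with values here, the steps that bear on this are a 2.0-fold higher number from compound 1 to compound 3 (0.30 log units; within the scatter) and a 2.4-fold higher number from compound 2 to compound 3 (0.38 log units; beyond the scatter), both moving from a named aryl group to thiophen-2-yl and both raising the number. Reversing that kind of change to phenyl is therefore expected to lower the number modestly, as a 1.7-fold lower number from compound 3 to compound 4 (0.24 log units; within the scatter). Compound 4 is expected to give 95 nM, in the range 45 nM to 200 nM.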

Compound 4, half-maximal inhibitory concentration: 117 nM
Compound 4: the middle estimate sits 1.2-fold (0.09 log units) below what was measured; low and high end bracket the measured number.
By their numbers in this assay, from the lowest: compounds 2, 1, 4 and 3 (each within the scatter of the next, the first and the last beyond it).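

In this assay, the change from thiophen-2-yl to phenyl gives a 1.4-fold lower number from compound 3 to compound 4 (0.15 log units; within the scatter) and the change from pyridin-4-yl to phenyl gives a 1.7-fold higher number from compound 2 to compound 4 (0.23 log units; within the scatter) and so neither separates phenyl from these groups at this aromatic carbon. Hydrogen in place of hydroxy gives a 1.4-fold higher number from compound 1 to compound 4 (0.15 log units; within the scatter) and so the hydroxy group of compound 1 is not needed for a number in this range. Nothing measured here explains these small steps. Open, on these data alone, is whether an amine or a carboxylic acid on the phenyl ring, or a longer chain in its place, would move the number beyond the scatter.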